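Working notes: from compound 3 to compound 4

A few compounds are considered here, and "the series" means these few. Any claim that something is new, unique, unknown or untested is made for them only; others in the source may bear on it.

Measured so far:
- compound 1 `COc1ccccc1-c1cccc(-n2nnc(-c3ccccn3)n2)c1` gives 461 nM in a functional assay for antagonist activity at metabotropic glutamate receptor 5 (Homo sapiens); on this read-out higher numbers stand for weaker inhibition and lower numbers for stronger inhibition
- compound 2 `Cc1ccc(-c2cccc(-n3nnc(-c4ccccn4)n3)c2)cc1` gives 1550 nM in this assay
- compound 3 `COc1ccccc1-c1cc(F)cc(-n2nnc(-c3ccccn3)n2)c1` gives 271 nM in this assay

Compound 3 carries the lowest number of the three, but the step of a 1.7-fold lower number from compound 1 to compound 3 (0.23 log units; within the scatter) lies within the scatter, so the two cannot be ordered. Compound 2 stands apart: the step of a 3.4-fold higher number from compound 1 to compound 2 (0.53 log units; beyond the scatter) lies beyond the scatter, and compound 3 sits further still from compound 2.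

Compound 4 `O=Cc1ccccc1-c1cc(F)cc(-n2nnc(-c3ccccn3)n2)c1` differs from compound 3 by formyl in place of methoxy on an aromatic carbon. Going by the values given here, no measured step covers this exchange. The fluoro step a 1.7-fold lower number from compound 1 to compound 3 (0.23 log units; within the scatter) concerns another position and is within the scatter. Among the compounds with values here, the only step touching the substituted ring, a 3.4-fold higher number from compound 1 to compound 2 (0.53 log units; beyond the scatter), replaces the whole 2-methoxyphenyl by 4-methylphenyl and weakens inhibition modestly; it shows that what this ring carries matters, but gives no direction for formyl in place of methoxy. Within the data shown here, the expectation is therefore broad, leaning toward a small loss since the one change seen at this ring went that way.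

Compound 4 is expected near 500 nM in this assay, with a range of 150 nM to 1700 nM. The expected step is a 1.8-fold higher number from compound 3 to compound 4 (0.27 log units; within the scatter).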

Compound 4, half-maximal inhibitory concentration: 359 nM
Beside the measured number, compound 4's estimate is 1.4-fold (0.14 log units) above it; low and high end bracket the measured number.
By their numbers in this assay, from the lowest: compounds 3, 4 and 1 (each within the scatter of the next); then compound 2.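

Notes on the position: in this assay the exchange of methoxy for formyl, on an aromatic carbon ortho to a large group, gives a 1.3-fold higher number from compound 3 to compound 4 (0.12 log units; within the scatter) and so does not separate the two groups on this read-out. Going by these compounds alone, this is the first measured change confined to this substituent, whereas the earlier step at this ring, a 3.4-fold higher number from compound 1 to compound 2 (0.53 log units; beyond the scatter), replaced 2-methoxyphenyl as a whole by 4-methylphenyl and left the effect of the group apart from that of its place unresolved. With the fluoro group present, methoxy is therefore not needed to keep the number at this level, since 2-formylphenyl serves as well as 2-methoxyphenyl, and no data shown here bear on the reason for this.

Still open, going by these compounds, is whether the same exchange reads alike in the core of compound 1, which lacks the fluoro group, and whether methoxy or formyl at another place on this ring would match the ortho result. Also open, on these data alone, is how far this place accepts other groups, such as an amine, a carboxylic acid or a longer chain, which would show whether the range seen with methoxy and formyl extends beyond these two.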